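This account rests on a few compounds, and the source may have more. Where it says the series, first, only, none or still open, it means among the compounds named here.

Measured so far, in a functional assay on a cell-free system (plasma) with sterol O-acyltransferase, Soat (Rattus norvegicus) as the target; on this read-out lower numbers stand for an effect already at smaller amounts and higher numbers for an effect only at larger amounts of compound:
Compound 1 `Cc1cc(C)c(NC(=O)N(Cc2cccc(-c3nnn(C)n3)c2)C2CCCCCC2)c(C)c1` gives < 1 mg/kg, which is a limit of the assay and not a number.
Compound 2 `Cc1cc(C)c(NC(=O)N(Cc2cccc(-c3nnnn3C)c2)C2CCCCCC2)c(C)c1` gives > 1 mg/kg, again a limit of the assay rather than a number.

Compound 2 thus stands only as a limit in this assay, at the weaker end of the two values shown. Among the measured compounds shown here, the one step connecting the measured compounds, a number no lower from compound 1 to compound 2 (the limit leaves the size open), has no readable size, as both of its ends sit at a limit: the limit of < 1 mg/kg in this assay, at which 1 of the 2 values shown sits, and (the limit of > 1 mg/kg in this assay, at which 1 of the 2 values shown sits).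

Compound 3 `Cc1cc(C)c(NC(=O)N(Cc2cccc(-n3cccc3)c2)C2CCCCCC2)c(C)c1` differs from compound 2 in a single place: 1H-pyrrol-1-yl in place of 1-methyl-1H-tetrazol-5-yl on an aromatic carbon. A five-membered aromatic ring with one hetero atom replaces one with four hetero atoms.

For the measured compounds named here, the only measured step bearing on this change is a number no lower from compound 1 to compound 2 (the limit leaves the size open), which exchanges one methyltetrazolyl isomer for another at the same carbon; its size is not readable, so it gives no scale for a move to a pyrrole. No direction can be expected with confidence in this assay. Compound 3 is therefore expected near compound 2, at an estimated 2 mg/kg, with a range from 0.5 mg/kg to 10 mg/kg, which means an expected step that the limit leaves unreadable from compound 2 to compound 3.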

Compound 3, dose for half-maximal effect: 0.17 mg/kg
For compound 3 the middle estimate is 12-fold (1.07 log units) above the measured one, and the stated range ends above it.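

In this assay, the aromatic carbon meta to a large group now yields a readable change: putting 1H-pyrrol-1-yl in place of 1-methyl-1H-tetrazol-5-yl gives an at least 5.8-fold lower number from compound 2 to compound 3 (0.76 log units; beyond the scatter). Until now this position had shown only limits. Compound 3 gives a true number, 0.17 mg/kg, so among the compounds shown a tetrazole ring is not needed here for an effect at small doses. The step between compound 1 and compound 3 cannot be read, because compound 1 is held only by a limit: the limit of < 1 mg/kg in this assay, at which 1 of the 3 values shown sits.

The compounds shown do not reveal whether the gain comes from the pyrrole ring itself, from the smaller count of hetero atoms, or from some other difference between the two rings, and they do not place compound 3 relative to compound 1. A simple amine, a carboxylic acid or a plain phenyl ring on the same carbon would test how far this position accepts groups unlike both the tetrazoles and the pyrrole.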